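Bromo for nitro on the amide ring: cytotoxicity notes

The source may hold more compounds than are shown below. What is called first, only, known or untested is meant among the compounds shown, and "the series" means these compounds.

Measured so far in an ADME assay on MT4 cells (Homo sapiens) for cytotoxicity; on this read-out lower numbers stand for higher toxicity in this test and higher numbers for lower toxicity in this test:
compound 1 `COc1ccc(-c2nnsc2SCC(=O)Nc2ccccc2Br)cc1` gives > 286000 nM
compound 2 `O=C(CSc1snnc1-c1ccc(Cl)cc1Cl)Nc1ccccc1[N+](=O)[O-]` gives > 283000 nM

Both numbers are limits of the assay, not measured values. Compound 1 sits at the limit of > 286000 nM in this assay, at which 1 of the 2 values shown sits. Compound 2 sits at the limit of > 283000 nM in this assay, at which 1 of the 2 values shown sits, so within the tested range it shows no measurable toxicity. Among the compounds with values here, the two measured compounds differ in more than one place, so no single step between them can be counted; their values simply both sit at a limit.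

Compound 3 `O=C(CSc1snnc1-c1ccc(Cl)cc1Cl)Nc1ccccc1Br` carries the change bromo in place of nitro on an aromatic carbon on the core of compound 2, which read one bond further out is 2-nitrophenyl to 2-bromophenyl. Compound 1 carries the same bromo group on its amide ring and gives > 286000 nM. The step that the limit leaves unreadable from compound 2 to compound 3 is therefore expected to be none beyond the scatter. Compound 3 is expected to give 285000 nM, in the range 140000 nM to 600000 nM, most likely reported again only as a limit.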

Compound 3, half-maximal cytotoxic concentration: >= 146000 nM
Compound 3: a limit, no number; the forecaster's own chance of this, stated with the estimate: 80%; the middle value lies beyond the limit too.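

The values of compound 1, compound 2 and compound 3 are all limits, so neither the step from compound 2 to compound 3 nor that from compound 1 to compound 3 can be read. The compounds shown leave open whether either change alters cytotoxicity at all.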